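A Hydroxy Group on the Ethyl Chain of Compound 3

The compounds below may be only part of what the source reports. "The series", "measured", "known", "first", "only" and "open" are said of these compounds alone.

Of the compounds shown here, three with a shared core have been tested in a functional assay on the whole organism with Rattus norvegicus as the target; a lower number here means that less compound is needed, a higher number that more compound is needed for the effect. Compound 1, `Nc1nc2ccc(C3CCCCC3)cc2s1`, gives in this assay > 10 mg/kg, which is a limit of the assay rather than a number. Compound 2, `Nc1nc2ccc(OC(F)(F)C(F)(F)F)cc2s1`, gives 2.5 mg/kg in this assay. Compound 3, `CCn1c(=N)sc2cc(OC(F)(F)F)ccc21`, gives 5 mg/kg in this assay, a value within the usual scatter of the number for compound 2, so the two cannot be told apart. Compound 4, `N=c1sc2cc(OC(F)(F)F)ccc2n1CCO`, is not yet measured; it differs from compound 3 by hydroxy in place of hydrogen on a saturated chain carbon, two bonds along the chain from an aromatic nitrogen. Among the measured compounds shown here, no measured pair shows what such a change does; the step in this assay is expected to be none beyond the scatter. Compound 4 is expected to give 5 mg/kg in this assay, between 2 mg/kg and 12 mg/kg, an expected step of no change at the digits printed from compound 3 to compound 4 (within the scatter).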

Compound 4, dose for half-maximal effect: 8 mg/kg
Compound 4: the middle estimate sits 1.6-fold (0.20 log units) below what was measured, within the range that was stated.
By their numbers in this assay, from the lowest: compounds 2, 3 and 4 (each within the scatter of the next, the first and the last beyond it). At a limit, above all of these: compound 1.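

In this assay, hydroxy in place of hydrogen on a saturated chain carbon, two bonds along the chain from an aromatic nitrogen, gives a 1.6-fold higher number from compound 3 to compound 4 (0.20 log units; within the scatter). So this position accepts ethyl changing to 2-hydroxyethyl with no change that can be told from the scatter, something the earlier compounds could not show. Nothing measured here points to a reason for this result.

Going by these compounds, what remains open is whether a longer chain, an amine or a carboxylic acid at this position would also leave the number within the scatter.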